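Benzyl to cyclohexyl on compound 3

The compounds below may be only part of what the source reports. "The series", "measured", "known", "first", "only" and "open" are said of these compounds alone.

In an ADME assay on CCRF-HSB-2 cells (Homo sapiens) for cytotoxicity, with a stated time of 7 days (a lower number here means that less compound is tolerated, a higher number that more compound is tolerated), compound 1 `CC(C)CSc1nc(N)nc2c1ncn2/C=C1/CC1(CO)CO` gives 60000 nM. Compound 2 `CCOc1nc(N)nc2c1ncn2/C=C1/CC1(CO)CO` reads > 20000 nM, which is a limit. Compound 3 `Nc1nc(NCc2ccccc2)c2ncn(/C=C3/CC3(CO)CO)c2n1` reads > 20000 nM, which is also a limit.

Compound 4 `Nc1nc(NC2CCCCC2)c2ncn(/C=C3/CC3(CO)CO)c2n1` carries cyclohexyl in place of benzyl on a nitrogen on an aromatic ring. Only changes of the group on the aromatic carbon have been measured so far. They are a step that the limit leaves unreadable from compound 1 to compound 3 and a step that the two limits leave unreadable from compound 2 to compound 3, alongside a step that the limit leaves unreadable from compound 1 to compound 2. None gives a size to carry over, so no step beyond the usual scatter is expected. The expected step is a step that the limit leaves unreadable from compound 3 to compound 4. The estimate for compound 4 is 40000 nM, within a range of 15000 nM to 100000 nM.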

Compound 4, half-maximal cytotoxic concentration: > 20000 nM
Compound 4: no number, only a limit; the forecaster's own chance of this, stated with the estimate: 65%; the middle value does not contradict the limit.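

Compound 4 also reads only as a limit, so the steps to it from compound 1, compound 2 and compound 3 cannot be read, because the values stop here: the limit of > 20000 nM in this assay, at which 3 of the 4 values shown sit. From the compounds shown here alone, whether cyclohexyl and benzyl differ in this assay stays open.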